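Propyl Sulfonamide Extension on the Azaindazole Core

A few compounds are considered here, and "the series" means these few. Any claim that something is new, unique, unknown or untested is made for them only; others in the source may bear on it.

In an assay for binding affinity to dual specificity mitogen-activated protein kinase kinase 4 (Homo sapiens), read by KINOMEscan, tested at 10 nM (a lower number here means a stronger effect, a higher number a weaker effect of the compound at the concentration tested), compound 2 `CS(=O)(=O)Nc1ccc(F)c(C(=O)c2n[nH]c3ncc(-c4ccc(S(N)(=O)=O)cc4)cc23)c1F` gives 12%. Its only measured neighbour, compound 1 `CCCS(=O)(=O)Nc1ccc(F)c(C(=O)c2n[nH]c3ncc(-c4ccc(S(N)(=O)=O)cc4)cc23)c1F`, gives 5.1% in this assay, and the step of a number 6.9 percentage points higher from compound 1 to compound 2 (within the scatter) leaves compound 2 at the larger of the two numbers shown without a difference beyond the scatter. Compound 3 `CCCCS(=O)(=O)Nc1ccc(F)c(C(=O)c2n[nH]c3ncc(-c4ccc(S(N)(=O)=O)cc4)cc23)c1F` carries propyl in place of hydrogen on a saturated chain carbon bound to a sulfonyl sulfur. The step from compound 1 to compound 2 is the only one that bears on this change, and it was small. Compound 3 is therefore expected to show a step of a number 6 percentage points lower from compound 2 to compound 3 (within the scatter), with no change beyond the scatter. Compound 3 is estimated at 6%, ranging from 1% to 16%.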

Compound 3, a percentage reported as activity, at one concentration (the size of the read-out at that concentration, not a potency): 6.9%
For compound 3 the middle estimate is 0.9 percentage points below the measured one, within the range that was stated.
By their numbers in this assay, from the lowest: compounds 1, 3 and 2 (each within the scatter of the next).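

Adding to the chain on the saturated carbon bound to the sulfonyl sulfur gives a number 5.1 percentage points lower from compound 2 to compound 3 (within the scatter) in this assay. Lengthening the chain by one carbon at its far end gives a number 1.8 percentage points higher from compound 1 to compound 3 (within the scatter). The methyl, propyl and butyl sulfonyl compounds therefore all lie within the scatter of one another, so the butyl chain of compound 3 adds no change that can be told from the scatter. No evidence at hand bears on this result. From the compounds shown here alone, whether a longer chain such as hexyl would stay within that scatter remains open, as does the effect of an amine or a carboxylic acid at the end of the chain.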